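Ethoxyphenyl variation on the triazole nitrogen of the spiro series

The compounds below may be only part of what the source reports. "The series", "measured", "known", "first", "only" and "open" are said of these compounds alone.

In a functional assay on MCF7 cells (Homo sapiens) for antiproliferative activity, read by MTT assay, with a stated time of 48 h (a lower number here means a stronger inhibitor, a higher number a weaker inhibitor), compound 1 `N#CC1=C(N)Oc2c(c3nc4ccccc4nc3c3ccccc23)C12C(=O)N(Cc1cnnn1-c1cccc(Cl)c1)c1ccccc12` gives 43600 nM, the only number shown in the set. Compound 2 `COc1ccc(-n2nncc2CN2C(=O)C3(C(C#N)=C(N)Oc4c3c3nc5ccccc5nc3c3ccccc43)c3ccccc32)cc1` reaches only the limit > 50000 nM in this assay. Compound 3 `CCOc1ccccc1-n1nncc1CN1C(=O)C2(C(C#N)=C(N)Oc3c2c2nc4ccccc4nc2c2ccccc32)c2ccccc21` likewise stops at the limit > 50000 nM. Compound 4 `CCOc1ccc(-n2nncc2CN2C(=O)C3(C(C#N)=C(N)Oc4c3c3nc5ccccc5nc3c3ccccc43)c3ccccc32)cc1` differs from compound 1 by 4-ethoxyphenyl in place of 3-chlorophenyl on an aromatic nitrogen. Within the data shown here, two measured steps bear on it: an at least 1.1-fold higher number from compound 1 to compound 2 (0.05 log units; that floor lies within the scatter) and an at least 1.1-fold higher number from compound 1 to compound 3 (0.05 log units; that floor lies within the scatter), both ending at the limit (the limit of > 50000 nM in this assay, at which 2 of the 3 values shown sit). Both aryl replacements on this nitrogen thus point toward a weaker inhibitor or no reading at all, so a step of similar or larger size in the same direction is expected for a 1.5-fold higher number from compound 1 to compound 4 (0.17 log units; within the scatter). Compound 4 is therefore estimated at 65000 nM, ranging from 35000 nM to 150000 nM, with a high chance that only a limit is reported.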

Compound 4, half-maximal inhibitory concentration: > 50000 nM
Compound 4: only a limit was reported (the forecaster's own chance of this, stated with the estimate: 70%); the middle value lies beyond the limit too.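

In this assay, 4-ethoxyphenyl on this aromatic nitrogen gives no number, the same outcome as 4-methoxyphenyl and 2-ethoxyphenyl, so moving the ethoxy group or adding the methyl yields no readable difference: the steps among compounds 2, 3 and 4 cannot be read. Among these compounds, the one readable step, an at least 1.1-fold higher number from compound 1 to compound 4 (0.05 log units; that floor lies within the scatter), gives only a floor. The reading for compound 4 is a limit, not a number, and most of the set now sits there: the limit of > 50000 nM in this assay, at which 3 of the 4 values shown sit.

Going by these compounds, whether any other group here separates from compound 1 at 43600 nM remains open. A phenyl bearing an amine or a carboxylic acid on this nitrogen would test that.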